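Alkyl chain length at the bromo position of compound 1

The compounds below may be only part of what the source reports. "The series", "measured", "known", "first", "only" and "open" are said of these compounds alone.

For the measured compounds named here, in an assay on CHO cells for antagonist activity at transient receptor potential cation channel subfamily V member 1 (Homo sapiens), read by FLIPR and calcium flux (a lower number here means a stronger inhibitor, a higher number a weaker inhibitor), compound 1 `CC(C(=O)NCc1ccc(C(F)(F)F)nc1Br)c1ccc(NS(C)(=O)=O)c(F)c1` gives 169 nM, the higher of the two numbers measured so far. Compound 2 `CCCc1nc(C(F)(F)F)ccc1CNC(=O)C(C)c1ccc(NS(C)(=O)=O)c(F)c1` gives 22.7 nM. The step of a 7.4-fold lower number from compound 1 to compound 2 (0.87 log units; beyond the scatter), propyl in place of bromo on an aromatic carbon, lies beyond the scatter. Compound 3 `CCCCCCc1nc(C(F)(F)F)ccc1CNC(=O)C(C)c1ccc(NS(C)(=O)=O)c(F)c1` carries hexyl in place of bromo on an aromatic carbon. Going by the values given here, only that one step bears on it, and the longer chain at the same place is expected to move the number in the same direction by a comparable amount, so a step of a 4.2-fold lower number from compound 1 to compound 3 (0.63 log units; beyond the scatter) is expected. Compound 3 is estimated at 40 nM, between 10 nM and 160 nM.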

Compound 3, inhibition constant: 1.6 nM
The estimate for compound 3 lay 25-fold (1.40 log units) above the measured number, and the stated range ends above it.
By their numbers in this assay, from the lowest: compound 3; then compound 2; then compound 1.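

At this place, on an aromatic carbon next to the ring nitrogen, the gain does not stop at propyl. In this assay, hexyl in place of bromo gives a 110-fold lower number from compound 1 to compound 3 (2.02 log units; beyond the scatter), and the extension from propyl to hexyl alone gives a 14-fold lower number from compound 2 to compound 3 (1.15 log units; beyond the scatter), so the longer chain accounts for much of the total. No available data bear on why the number falls with chain length.

On these data alone, whether octyl or a longer chain extends this trend remains open. So does whether a branched chain, an ether chain or a phenyl ring would match hexyl here.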